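Chloro to trifluoromethyl swap in the series

This account rests on a few compounds, and the source may have more. Where it says the series, first, only, none or still open, it means among the compounds named here.

Measured in a functional assay (aorta) for inhibition, with Rattus norvegicus as the target; on this read-out lower numbers stand for stronger inhibition and higher numbers for weaker inhibition:
- compound 1 `Cc1nsc(-c2ccc(N3CCN(c4cccc(Cl)c4)CC3)nn2)n1` gives 0.6 nM
- compound 2 `Cc1nsc(-c2nccc(N3CCN(c4cccc(C(F)(F)F)c4)CC3)n2)n1` gives > 100 nM (a limit of the assay, not a number)

Among the measured compounds shown here, compound 1 carries the only actual number so far in this assay (0.6 nM), so it can be ranked against no other measured number. The reading for compound 2 (> 100 nM) is a limit.

Compound 3 `Cc1nsc(-c2ccc(N3CCN(c4cccc(C(F)(F)F)c4)CC3)nn2)n1` has not yet been measured. It differs from compound 1 by trifluoromethyl in place of chloro on an aromatic carbon, meta to a large group (trifluoromethyl in place of chloro on an aromatic carbon). For the measured compounds named here, no measured pair shows this swap, so the expectation rests on the value of compound 1 (0.6 nM) and on the structural change alone.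

A modest loss of inhibition is expected in this assay, with a small chance that the change stays within the scatter. The estimated step is a 2.5-fold higher number from compound 1 to compound 3 (0.40 log units; beyond the scatter). A number rather than a limit is expected. For compound 3 the estimate is 1.5 nM, with an expected range from 0.3 nM to 10 nM.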

Compound 3, half-maximal inhibitory concentration: 0.3 nM
Beside the measured number, compound 3's estimate is 5.0-fold (0.70 log units) above it; low and high end bracket the measured number.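

In this assay, the position tolerates trifluoromethyl in place of chloro: the change gives a 2.0-fold lower number from compound 1 to compound 3 (0.30 log units; within the scatter). Among the compounds shown here, this is the first comparison that differs in one place only, and it shows that trifluoromethyl, with 4 heavy atoms, can stand in for chloro, with 1 heavy atom, on this aromatic carbon of the core of compound 1 without a loss beyond the scatter. The trifluoromethyl group alone therefore does not account for the reading of compound 2, which has the same group on a different core and gives a limit of the assay rather than a number: the limit of > 100 nM in this assay, at which 1 of the 3 values shown sits.

Still open, from the compounds shown here alone, is how far this tolerance extends to groups of a different kind at the same position, such as an amine, a carboxylic acid or a methoxy group, since chloro and trifluoromethyl are the only two compared here. Also open, going by these compounds, is how the core of compound 2 behaves with chloro in place of trifluoromethyl, which would show whether the swap reads the same on that core as on the core of compound 1.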